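The compounds below may be only part of what the source reports. "The series", "measured", "known", "first", "only" and "open" are said of these compounds alone.

Compound 2 `Nc1nc(NCCNc2ncc(-c3ncc[nH]3)c(-c3ccc(F)cc3Cl)n2)ccc1[N+](=O)[O-]` stands only at a limit in an ADME assay on microsomes from liver (Rattus norvegicus) for metabolic stability; on this read-out lower numbers stand for a shorter-lived compound and higher numbers for a longer-lived compound: there compound 2 gives > 0.5 h, which is a limit of the assay and not a number. Compound 1 `Nc1nc(NCCNc2ncc(-c3ncc[nH]3)c(-c3cc(F)ccc3F)n2)ccc1[N+](=O)[O-]` likewise gives > 0.5 h, again a limit. Among the compounds with values here, the single measured step, a step that the two limits leave unreadable from compound 1 to compound 2, is therefore unreadable, since both values sit at the limit of > 0.5 h in this assay, at which 2 of the 2 values shown sit. Compound 3 `Nc1nc(NCCNc2ncc(-c3ncc[nH]3)c(-c3ccc(Cl)cc3Br)n2)ccc1[N+](=O)[O-]` carries 2-bromo-4-chlorophenyl in place of 2-chloro-4-fluorophenyl on an aromatic carbon. With no readable step to lean on, the expected change is a step that the limit leaves unreadable from compound 2 to compound 3, within the scatter. Compound 3 is accordingly estimated at 0.8 h, between 0.4 h and 1.6 h.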

Compound 3, half-life: > 0.5 h
Compound 3 was reported as a limit (the forecaster's own chance of this, stated with the estimate: 60%); the middle value does not contradict the limit.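

No new step can be read among compound 1, compound 2 and compound 3, because all three stand at a limit: the limit of > 0.5 h in this assay, at which 3 of the 3 values shown sit. The compounds shown leave open how long each actually lasts in this assay, and whether the exchanged groups change that at all.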